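The source may report more compounds than this note shows. Statements on the series, on what has been measured and on what is new or still open speak of the compounds shown alone.

Compound 1 `CC(C)C[C@H](N)CCN(C(=O)[C@@H]1C[C@H]1c1ccccc1)c1ccc(-c2ccccc2)cc1` — 3 nM
Compound 2 `CC[C@H](C)[C@H](N)CN(C(=O)[C@@H]1C[C@H]1c1ccccc1)c1ccc(-c2ccc(C(C)(C)C)cc2)cc1` — 750 nM

Within the data shown here, in a functional assay for agonist activity at G protein-coupled receptor 88 (Homo sapiens), read by HTRF and cAMP accumulation (a higher number here means that more compound is needed for the effect, a lower number that less compound is needed), compound 2 gives the higher of the two numbers, and compound 1 sits far lower; the two structures differ in more than one place, so no single step connects them. Compound 3 `CC[C@H](C)[C@H](N)CN(C(=O)[C@@H]1C[C@H]1c1ccccc1)c1ccc(-c2ccc(CN)cc2)cc1` differs from compound 2 in one place: aminomethyl in place of tert-butyl on an aromatic carbon. Among the measured compounds shown here, no measured step speaks to this change, so the expectation rests only on compound 2 giving 750 nM in this assay. A moderate move toward a lower number is expected, a 3.8-fold lower number from compound 2 to compound 3 (0.57 log units; beyond the scatter), with wide uncertainty. Compound 3 is estimated at 200 nM, in the range 30 nM to 1500 nM.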

Compound 3, half-maximal effective concentration: > 30000 nM
Compound 3 gave a limit, no number; the forecaster's own chance of this, stated with the estimate: 10%; middle value at least 150-fold (2.17 log units) from the limit.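

This position on the outer aromatic ring is sensitive to what it carries: in this assay, aminomethyl in place of tert-butyl gives an at least 40-fold higher number from compound 2 to compound 3 (1.60 log units; beyond the scatter). Among these compounds, the earlier compounds held no single-place change, so this is the first direct reading of any one group's effect. Compound 3 gives only a limit of the assay, not a number: the limit of > 30000 nM in this assay, at which 1 of the 3 values shown sits.

Only one replacement for tert-butyl stands at this position, so the loss of tert-butyl and the arrival of the amine cannot be told apart. A methyl or a hydroxymethyl group here remains an open case.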